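The compounds below may be only part of what the source reports. "The series", "measured", "known", "first", "only" and "open" are said of these compounds alone.

In a functional assay on A-375 cells (Homo sapiens) for cytotoxicity, read by MTT assay, with a stated time of 72 h (on this read-out higher numbers stand for weaker inhibition and lower numbers for stronger inhibition), compound 1 (`O=C1c2c[n+]([O-])c3ccccc3c2C(=O)c2c1c1ccccc1n2Cc1cn([C@H]2O[C@H](CO)[C@@H](O)[C@H]2O)nn1`) gives 340 nM and compound 2 (`O=C1c2c[n+]([O-])c3ccccc3c2C(=O)c2c1c1ccccc1n2CCCCN1CCNCC1`) gives 460 nM, so these two values lie within the scatter of each other. Compound 3 (`CN(C)CCCCn1c2c(c3ccccc31)C(=O)c1c[n+]([O-])c3ccccc3c1C2=O`) has not yet been measured. It departs from compound 2 by a single change: dimethylamino in place of piperazin-1-yl on a saturated chain carbon, four bonds along the chain from an aromatic nitrogen. For the measured compounds named here, no measured step of this kind is available, so no shift beyond the scatter is expected in this assay, in either direction. The estimated result is a 1.2-fold lower number from compound 2 to compound 3 (0.06 log units; within the scatter). For compound 3 the expected value is 400 nM, with an estimated range of 130 nM to 1200 nM.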

Compound 3, half-maximal inhibitory concentration: 470 nM
The estimate for compound 3 lay 1.2-fold (0.07 log units) below the measured number; the range from low to high includes it.
By their numbers in this assay, from the lowest: compounds 1, 2 and 3 (each within the scatter of the next).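

In this assay, dimethylamino in place of piperazin-1-yl on a saturated chain carbon, four bonds along the chain from an aromatic nitrogen, gives a 1.0-fold higher number from compound 2 to compound 3 (0.01 log units; within the scatter). This first step at this position shows that the six-membered ring and its hydrogen-bond donor are not needed to keep the value within the scatter of compound 2. Nothing measured here bears on why that is so. The compounds shown leave open how a carboxylic acid in place of the amine would read in this assay. They also leave open how dimethylamino would read on a shorter or longer chain.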